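A Phenethyl Swap on Compound 2

The compounds below may be only part of what the source reports. "The series", "measured", "known", "first", "only" and "open" are said of these compounds alone.

In a functional assay on CCRF-CEM cells (Homo sapiens) (on this read-out lower numbers stand for stronger inhibition and higher numbers for weaker inhibition), compound 1 (`O=C1CCCC/C1=C\c1ccc(OC(=O)c2ccc(Cl)cc2)cc1`) gives 41000 nM and compound 2 (`COc1ccc(C(=O)Oc2ccc(/C=C3\CCCCC3=O)cc2)cc1`) gives 36100 nM. Going by the values given here, these are the only two numbers available, and they lie within the scatter of each other, so compound 2 holds no distinct rank. Among the compounds with values here, the single measured step, a 1.1-fold lower number from compound 1 to compound 2 (0.06 log units; within the scatter), is methoxy in place of chloro on an aromatic carbon and does not exceed the scatter.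

Compound 3 (`O=C(CCc1ccccc1)Oc1ccc(/C=C2\CCCCC2=O)cc1`) has not yet been measured. Its change from compound 2 is phenethyl in place of 4-methoxyphenyl on a carbonyl carbon. The measured step bears on this only weakly, since it exchanged one substituent, whereas here the whole group is replaced. Within the data shown here, no measured compound carries a phenethyl group, so the range must stay wide. Among the measured compounds shown here, with a 1.1-fold lower number from compound 1 to compound 2 (0.06 log units; within the scatter) as the only guide, no change beyond the scatter is expected in this assay. The expected step is a 1.0-fold lower number from compound 2 to compound 3 (0.01 log units; within the scatter). For compound 3 the estimated value is 35000 nM, with an expected range of 15000 nM to 80000 nM.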

Compound 3, half-maximal inhibitory concentration: 34400 nM
For compound 3 the middle estimate is 1.0-fold (0.01 log units) above the measured one; measured number inside the range.
By their numbers in this assay, from the lowest: compounds 3, 2 and 1 (each within the scatter of the next).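

In this assay, the measured steps now reach beyond a single substituent, since the whole group on the carbonyl carbon is exchanged: a 1.0-fold lower number from compound 2 to compound 3 (0.02 log units; within the scatter) and a 1.2-fold lower number from compound 1 to compound 3 (0.08 log units; within the scatter) both lie within the scatter. Phenethyl thus stands level with 4-methoxyphenyl and with the 4-chlorophenyl of compound 1 at this position, even though phenethyl has no hydrogen-bond acceptor and 4-methoxyphenyl has one, so that difference in count comes with no step beyond the scatter across these compounds. Nothing available explains why the three compounds lie so close together.

On these data alone, whether this tolerance extends to groups without an aromatic ring on the carbonyl carbon stays open, for instance an amine, a carboxylic acid or a longer chain in place of phenethyl. All three compounds also share the same core, so the compounds shown say nothing about how the number would respond to a change there, such as a hydroxyl or a fluoro on that core.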